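Swapping a pyridine for a phenyl: expected clearance shift

The source may report more compounds than this note shows. Statements on the series, on what has been measured and on what is new or still open speak of the compounds shown alone.

Measured compounds and their clearance values:
- compound 1, `CN1C(=O)C2=C(C1=O)N(CC(=O)Nc1ccc(-c3cccnc3)nc1)CCC2`: 17 mL.min-1.g-1
- compound 2, `CN1C(=O)C2=C(C1=O)N(CC(=O)Nc1ccc(-c3ccccc3)nn1)CCC2`: 36 mL.min-1.g-1
- compound 3, `CN1C(=O)C2=C(C1=O)N(CC(=O)Nc1ccc(-c3cccnc3)cc1)CCC2`: 48 mL.min-1.g-1

All three compounds were run in an ADME assay on microsomes from liver (Mus musculus) for metabolic stability; on this read-out lower numbers stand for slow clearance and higher numbers for fast clearance. Compound 1 gives the lowest of the three numbers. Its nearest neighbour is compound 2, which gives 36 mL.min-1.g-1, a number beyond the scatter of this assay; furthest away is compound 3, which gives 48 mL.min-1.g-1, also beyond the scatter. Compound 1 is therefore the slowest-cleared compound of the three shown.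

Compound 4, `CN1C(=O)C2=C(C1=O)N(CC(=O)Nc1ccc(-c3ccccc3)nc1)CCC2`, has not yet been run in this assay. It differs from compound 1 in one place: phenyl in place of pyridin-3-yl on an aromatic carbon. The shared core and the amide linkage are untouched.

No pair of measured compounds differs only in this way, so the size of the step has to be estimated from the spread of the three numbers shown. Compound 2 and compound 3 both sit beyond the scatter above compound 1, and compound 4 is expected to move in the same direction, with a step from compound 1 to compound 4 of a 2.1-fold higher number from compound 1 to compound 4 (0.31 log units; beyond the scatter) in this assay. Compound 4 is thus estimated to give 35 mL.min-1.g-1 in this assay, within a range of 15 mL.min-1.g-1 to 80 mL.min-1.g-1.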

Compound 4, intrinsic clearance in microsomes in the liver assay: 13 mL.min-1.g-1
For compound 4 the middle estimate is 2.7-fold (0.43 log units) above the measured one, and the stated range ends above it.
By their numbers in the liver assay, from the lowest: compounds 4 and 1 (each within the scatter of the next); then compounds 2 and 3 (each within the scatter of the next).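

In the liver assay, phenyl in place of pyridin-3-yl gives a 1.3-fold lower number from compound 1 to compound 4 (0.12 log units; within the scatter), so compound 1 and compound 4 cannot be told apart on clearance, and this pair gives no sign that the ring nitrogen of the pyridin-3-yl group is needed for slow clearance. The same pair reads very differently in a physicochemical assay for solubility, measured as thermodynamic solubility, at pH 7.4 (a lower number here means a less soluble compound, a higher number a more soluble compound), where compound 1 gives 13 ug/mL and compound 4 gives 0.75 ug/mL. At this place on the ring, next to the ring nitrogen and para to a large group, the swap removes one ring nitrogen and its hydrogen-bond acceptor, and it costs solubility with no clearance difference to set against that loss: the measured solubility of compound 1, 13 ug/mL, and of compound 4, 0.75 ug/mL, a 17-fold lower number (1.24 log units; beyond the scatter)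

The compounds shown leave open whether another group in this place, such as a pyrimidin-5-yl ring, a morpholine or a carboxylic acid, would give higher solubility than the pyridin-3-yl group while keeping clearance as slow. They also leave open whether the same swap would behave alike on a different central ring, since neither compound 2 nor compound 3 has a partner that differs from it only in this way.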